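The source may hold more compounds than are shown below. What is called first, only, known or untested is meant among the compounds shown, and "the series" means these compounds.

Within the data shown here, compound 1 `COc1cccc(/C=C/C(=O)c2sc(Nc3ccc(Cl)c(Cl)c3)nc2C)c1` gives 8350 nM in a functional assay on BGC-823 cells (Homo sapiens) for cytotoxicity, read by MTT assay (a higher number here means a weaker inhibitor, a lower number a stronger inhibitor), and is the one numbered value in the set. Compound 2 `COc1ccc(/C=C/C(=O)c2sc(Nc3ccc(Cl)c(Cl)c3)nc2C)cc1` reaches only a limit of this assay, > 25000 nM. The step of an at least 2.9-fold higher number from compound 1 to compound 2 (0.47 log units; beyond the scatter) concerns the methoxyphenyl alone and rests on (the limit of > 25000 nM in this assay, at which 1 of the 2 values shown sits). Compound 3 `COc1cccc(/C=C/C(=O)c2sc(Nc3cccc(C)c3)nc2C)c1` differs from compound 1 at another place: 3-methylphenyl in place of 3,4-dichlorophenyl on a nitrogen on an aromatic ring. Among the measured compounds shown here, no measured step touches the group on the ring nitrogen, so nothing sizes this change. Compound 3 is therefore expected close to compound 1, an estimated 1.2-fold higher number from compound 1 to compound 3 (0.08 log units; within the scatter), with a wide range. For compound 3 the estimate in this assay is 10000 nM, between 3000 nM and 30000 nM.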

Compound 3, half-maximal inhibitory concentration: > 25000 nM
Compound 3: a limit, no number; the forecaster's own chance of this, stated with the estimate: 30%; at least 2.5-fold (0.39 log units) between middle value and limit.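

The group on the nitrogen now has a measured step, an at least 2.9-fold higher number from compound 1 to compound 3 (0.47 log units; beyond the scatter), so 3-methylphenyl in place of 3,4-dichlorophenyl at this position does register in this assay. Compound 3 stands only at a limit, > 25000 nM, so the step has a lower bound and no full size. The reading of this step rests on that limit: the limit of > 25000 nM in this assay, at which 2 of the 3 values shown sit.

Which of the two chlorines carries the difference stays open. So does how a 3-chlorophenyl or a 4-chlorophenyl on the same nitrogen would read.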